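This account rests on a few compounds, and the source may have more. Where it says the series, first, only, none or still open, it means among the compounds named here.

Of the compounds shown here, three built on the same core have been measured in a functional assay (aorta) with Oryctolagus cuniculus as the target; on this read-out lower numbers stand for tighter binding and higher numbers for weaker binding. Compound 1 `COc1cc(C(C)=O)ccc1OCCCN1CCC(C(c2ccc(F)cc2F)c2ccc(F)cc2F)CC1` gives 15.9 nM. Compound 2 `COc1cc(C(C)=O)ccc1OCCCCCN1CCC(C(c2ccc(F)cc2)c2ccc(F)cc2)CC1` gives 3.16 nM. Compound 3 `N#Cc1ccc(OCCCN2CCC(C(c3ccc(F)cc3)c3ccc(F)cc3)CC2)cc1` gives 5.01 nM. Among these three numbers compound 3 stands second highest. Its nearest neighbour is compound 2, whose value lies within the usual scatter of repeated measurements, so the two cannot be told apart on this evidence. Compound 1 lies furthest away, beyond the scatter, and carries the higher number of the pair.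

Compound 4 `CN(CCCN1CCC(C(c2ccc(F)cc2)c2ccc(F)cc2)CC1)c1ccccc1` has not yet been tested. It differs from compound 3 in one place:

methyl(phenyl)amino in place of 4-cyanophenoxy on a saturated chain carbon, three bonds along the chain from an amine nitrogen in a ring

Among the measured compounds shown here, no pair of measured compounds differs in exactly this way, so there is no directly comparable step to lean on. The three measured values occupy a narrow band, from compound 2 at 3.16 nM to compound 1 at 15.9 nM, and the change to compound 4 touches only the outer end of the chain. A modest shift toward a higher number is therefore expected, with the step from compound 3 to compound 4 estimated at a 1.6-fold higher number from compound 3 to compound 4 (0.20 log units; within the scatter). Compound 4 is expected to give about 8 nM in this assay, with a plausible range from 2.5 nM to 25 nM.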

Compound 4, dissociation constant: 2 nM
Beside the measured number, compound 4's estimate is 4.0-fold (0.60 log units) above it; the measured number lies below the stated range.
By their numbers in this assay, from the lowest: compounds 4, 2 and 3 (each within the scatter of the next, the first and the last beyond it); then compound 1.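

In this assay, putting methyl(phenyl)amino in place of 4-cyanophenoxy on a saturated chain carbon, three bonds along the chain from an amine nitrogen in a ring, gives a 2.5-fold lower number from compound 3 to compound 4 (0.40 log units; beyond the scatter), a step that lies beyond the usual scatter. This shows that the group at the outer end of the chain can be exchanged without losing tight binding, and that the exchange can move the number measurably toward tighter binding. The swap removes the nitrile and replaces the oxygen with a nitrogen carrying a methyl group all at once, and no measurement shown explains why the number falls or which of these parts matters.

On these data alone, it remains open how a plain phenoxy group or a phenylamino group without the methyl would read at this same chain end, and either would help split the swap into its separate parts. As far as these compounds go, it is also open whether methyl(phenyl)amino would keep this lower number on a longer chain, such as a pentyl chain.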